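This account rests on a few compounds, and the source may have more. Where it says the series, first, only, none or still open, it means among the compounds named here.

Measured so far:
- compound 1 `CCOc1ccc2c(=O)c(-c3ccc(O)cc3)coc2c1`: 95.6%
- compound 2 `O=c1c(-c2ccc(O)cc2)coc2cc(CC3OC(CO)C(O)C(O)C3O)ccc12`: 0%

Of the compounds shown here, two have been tested in a functional assay on mitochondria (Cricetulus griseus) for inhibition of Monoamine oxidase (Homo sapiens), tested at 3 uM; on this read-out lower numbers stand for a weaker effect and higher numbers for a stronger effect at the one concentration tested. Compound 1 gives 95.6%, the higher of the two numbers. Compound 2 gives 0%, a number far below that of compound 1 and well beyond the usual scatter. Within the data shown here, compound 2 differs from compound 1 in more than one place, so no single step between measured compounds can be read off; the only anchor is the value of compound 1.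

Compound 3 `O=c1c(-c2ccc(O)cc2)coc2cc(OCCCBr)ccc12` has not been measured. It differs from compound 1 in one place: bromomethyl in place of hydrogen on a saturated chain carbon, two bonds along the chain from an oxygen on an aromatic ring. Seen one bond further out, this is a change of ethoxy to 3-bromopropoxy, with the shared core otherwise untouched.

Compound 1 already stands close to complete inhibition at this concentration, so there is little room for a higher number. The step from compound 1 to compound 3 is expected to be small, likely within the scatter or a mild decrease, estimated as a number 7.6 percentage points lower from compound 1 to compound 3 (within the scatter). Compound 3 is therefore expected to give about 88%, with a likely range from 65% to 99%.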

Compound 3, a percentage reported as inhibition, at one concentration (the size of the read-out at that concentration, not a potency): 90.8%
Estimate against measurement, compound 3: 2.8 percentage points below, and the stated range covers the measured number.
By their numbers in this assay, from the lowest: compound 2; then compounds 3 and 1 (each within the scatter of the next).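

In this assay, among these compounds, replacing ethoxy with 3-bromopropoxy gives a number 4.8 percentage points lower from compound 1 to compound 3 (within the scatter) and is the first reading of a single change at this position, since the earlier comparison offered no one-place step. It shows that, on the shared core, bromomethyl can take the place of hydrogen on a saturated chain carbon, two bonds along the chain from an oxygen on an aromatic ring, without a shift beyond the usual scatter at this one concentration. Nothing measured here gives a reason for this result.

The compounds shown leave open whether the bromine or the added chain carbon accounts for the reading, as they include no plain propoxy chain, and they do not show how an amine or a carboxylic acid at the chain end, or a longer chain, would read. Compound 1 and compound 3 both lie high on this single-concentration read-out, so any difference in potency between them also remains unresolved, and testing at lower concentrations would be needed to expose one.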